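Replacing the Pyrrolidinyl Group of Compound 2

The source may hold more compounds than are shown below. What is called first, only, known or untested is meant among the compounds shown, and "the series" means these compounds.

Compound 1 `Cc1nnc(CN2CCCC2)n1-c1ccc(Cl)cc1Cc1ccccc1` gives > 100 mg/kg in a functional assay on the whole organism (strain CF-1) for inhibition, with Mus musculus as the target (a higher number here means that more compound is needed for the effect, a lower number that less compound is needed), which is a limit of the assay and not a number.
Compound 2 `Cc1nnc(CN2CCCC2)n1-c1ccc(Cl)cc1C(=O)c1ccccc1` gives 2 mg/kg in this assay.

Compound 2 thus holds the only number shown; the other value is a limit, as the limit of > 100 mg/kg in this assay, at which 1 of the 2 values shown sits, records. Within the data shown here, the single measured step, an at least 50-fold lower number from compound 1 to compound 2 (1.69 log units; beyond the scatter), concerns benzoyl in place of benzyl on an aromatic carbon. Compound 3 `CCNCc1nnc(C)n1-c1ccc(Cl)cc1C(=O)c1ccccc1` differs from compound 2 at another place: ethylamino in place of pyrrolidin-1-yl on a saturated chain carbon bound to an aromatic carbon. Among the measured compounds shown here, no measured step touches that position, so that large step gives no guide here, and no change beyond the scatter is expected. The estimate for compound 3 in this assay is 3 mg/kg, between 1 mg/kg and 12 mg/kg. That expectation amounts to a 1.5-fold higher number from compound 2 to compound 3 (0.18 log units; within the scatter).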

Compound 3, dose for half-maximal effect: 0.5 mg/kg
Compound 3: the middle estimate sits 6.0-fold (0.78 log units) above what was measured; the whole stated range lies above it.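

Replacing the ring with an open chain at this position gives a 4.0-fold lower number from compound 2 to compound 3 (0.60 log units; beyond the scatter), so the pyrrolidin-1-yl ring is not needed for a low number in this assay. The position therefore responds to change, and ethylamino does better here than the ring it replaces. Among these compounds, nothing measured so far accounts for this gain. Ethylamino differs from pyrrolidin-1-yl both in having no ring and in carrying a hydrogen-bond donor, and these two compounds cannot separate those differences. As far as these compounds go, how a dimethylamino group or a longer chain such as propylamino would compare remains open.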